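Adding Chloro to the Trifluoromethylphenyl Urea

The source may report more compounds than this note shows. Statements on the series, on what has been measured and on what is new or still open speak of the compounds shown alone.

Going by the values given here, compound 2 `COc1cc2cc(Oc3ccc(NC(=O)Nc4cccc(C(F)(F)F)c4)cc3)c(C)nc2cc1OC` holds the lower of the two numbers measured so far in a functional assay on A498 cells (Homo sapiens) for inhibition, read by sulforhodamine B assay, with a stated time of 48 h, tested at 10 uM; a lower number here means a stronger effect, a higher number a weaker effect of the compound at the concentration tested: compound 2 gives 21.7%, whereas compound 1 `COc1cc2cc(Oc3ccc(NC(=O)Nc4ccccc4)cc3)c(C)nc2cc1OC` gives 54%. Among the compounds with values here, the only measured step, a number 32.3 percentage points lower from compound 1 to compound 2 (beyond the scatter), shows that a single group placed on this ring can move the read-out a long way. Compound 3 `COc1cc2cc(Oc3ccc(NC(=O)Nc4ccc(Cl)c(C(F)(F)F)c4)cc3)c(C)nc2cc1OC` differs from compound 2 by chloro in place of hydrogen on an aromatic carbon. Within the data shown here, no measured step covers the entry of a chloro group, so the size and direction of the coming change rest on that one neighbouring step alone. A number somewhat lower than that of compound 2, or no change beyond the scatter, is expected. The estimated step is a number 6.7 percentage points lower from compound 2 to compound 3 (within the scatter). Compound 3 is therefore expected to give about 15% in this assay, with a likely range from 4% to 30%.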

Compound 3, a percentage reported as activity, at one concentration (the size of the read-out at that concentration, not a potency): 10.5%
Estimate against measurement, compound 3: 4.5 percentage points above; the measured number falls inside the stated range.
By their numbers in this assay, from the lowest: compound 3; then compound 2; then compound 1.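

In this assay, placing chloro ortho to the trifluoromethyl group and para to a large group gives a number 11.2 percentage points lower from compound 2 to compound 3 (beyond the scatter) on a ring that already carries trifluoromethyl, so this ring can still respond to a second group. The full change from phenyl to 4-chloro-3-(trifluoromethyl)phenyl gives a number 43.5 percentage points lower from compound 1 to compound 3 (beyond the scatter) and is the largest step among these compounds. Nothing available explains why either step goes in this direction.

The compounds shown leave open whether chloro would lower the number in the same way on a ring without trifluoromethyl. They also leave open how other groups would behave at this same position, such as bromo, a methoxy group or an amine, and so whether the effect is particular to chloro.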